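Swapping thiophen-3-yl for 2-chlorophenyl in a weak compound

The compounds below may be only part of what the source reports. "The series", "measured", "known", "first", "only" and "open" are said of these compounds alone.

Measured in a functional assay on Z-138 cells (Homo sapiens) for antiproliferative activity, with a stated time of 72 h; a higher number here means a weaker inhibitor, a lower number a stronger inhibitor
- compound 1 `CCCCC#Cc1cc([C@@H]2O[C@H](CO)[C@@H](O)[C@H]2O)n2ncnc(N)c12` gives 200 nM
- compound 2 `Nc1ncnn2c([C@@H]3O[C@H](CO)[C@@H](O)[C@H]3O)cc(-c3ccsc3)c12` gives 43500 nM

Within the data shown here, of these two numbers, the one for compound 2 is the higher, which makes it the weaker inhibitor of the pair. Next comes compound 3 `Nc1ncnn2c([C@@H]3O[C@H](CO)[C@@H](O)[C@H]3O)cc(-c3ccccc3Cl)c12`, which keeps the shared core and has 2-chlorophenyl in place of thiophen-3-yl on an aromatic carbon. Among the measured compounds shown here, only one measured step touches this place, the large 220-fold higher number from compound 1 to compound 2 (2.34 log units; beyond the scatter) on replacing the hex-1-yn-1-yl chain with thiophen-3-yl. That step exchanged a chain for a ring, whereas the new change exchanges one aromatic ring for another, and no such swap has been measured. In this assay no shift beyond the scatter is therefore expected, with compound 2 at 43500 nM as the anchor. The estimated step is a 1.1-fold lower number from compound 2 to compound 3 (0.04 log units; within the scatter) in size. For compound 3 the estimated value is 40000 nM, with an expected range of 10000 nM to 100000 nM.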

Compound 3, half-maximal inhibitory concentration: 76100 nM
Beside the measured number, compound 3's estimate is 1.9-fold (0.28 log units) below it, within the range that was stated.
By their numbers in this assay, from the lowest: compound 1; then compounds 2 and 3 (each within the scatter of the next).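

In this assay, exchanging one aromatic ring for another at this position gives a shift that cannot be told from the scatter (a 1.7-fold higher number from compound 2 to compound 3 (0.24 log units; within the scatter)). A five-membered aromatic ring with sulfur and a six-membered carbon ring carrying chlorine thus read alike here, and the large gap to the hex-1-yn-1-yl chain appears with this ring as well (a 380-fold higher number from compound 1 to compound 3 (2.58 log units; beyond the scatter)). Nothing available explains why compound 1 stands so far from the two ring compounds.

Going by these compounds, whether a shorter alkyne chain, a saturated hexyl chain or a phenyl ring carrying an amine would come closer to compound 1 remains open. Also open, on these data alone, is what the chlorine itself contributes in compound 3, a question that a plain phenyl group could answer.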